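This account rests on a few compounds, and the source may have more. Where it says the series, first, only, none or still open, it means among the compounds named here.

Of the compounds shown here, three built on one shared core have been measured in an assay on isolated protein for agonist activity at Bile acid receptor (Homo sapiens), read by TR-FRET, with a stated time of 3 h, in the absence of a further agent; on this read-out lower numbers stand for an effect already at smaller amounts and higher numbers for an effect only at larger amounts of compound. Compound 1 `CCCCOc1cccc(C(=O)Nc2cccc(C(=O)O)c2)c1` gives 3150 nM. Compound 2 `CC(C)COc1cccc(C(=O)Nc2cccc(C(=O)O)c2)c1` gives 1130 nM, and compound 3 `O=C(O)c1cccc(NC(=O)c2cccc(OCc3ccccc3)c2)c1` gives 1160 nM. Among these three numbers compound 3 stands second highest; its nearest neighbour is compound 2, whose number lies within the scatter of its own, while compound 1 lies furthest away. All measured steps concern the saturated chain carbon bound to the oxygen on the aromatic ring: a 2.8-fold lower number from compound 1 to compound 2 (0.45 log units; beyond the scatter), a 2.7-fold lower number from compound 1 to compound 3 (0.43 log units; beyond the scatter), and a 1.0-fold higher number from compound 2 to compound 3 (0.01 log units; within the scatter). Compound 4 `O=C(O)c1cccc(NC(=O)c2cccc(-c3ccccc3)c2)c1` has not yet been measured. It differs from compound 3 by phenyl in place of benzyloxy on an aromatic carbon. Going by the values given here, no measured step removes the oxygen and the chain carbon in this way; the three known steps only exchange what sits on that chain carbon, and they show modest movements at most. The change to compound 4 is thus of a kind the data do not cover, and a number near that of compound 3, perhaps somewhat higher, is expected with wide uncertainty. Compound 4 is estimated at 2000 nM, within a range from 600 nM to 7000 nM. This estimate means a step of a 1.7-fold higher number from compound 3 to compound 4 (0.24 log units; within the scatter), which is expected to stay within the scatter.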

Compound 4, half-maximal effective concentration: 25 nM
Compound 4: middle estimate off by 80-fold (1.90 log units), on the high side; the measured number lies below the stated range.
By their numbers in this assay, from the lowest: compound 4; then compounds 2 and 3 (each within the scatter of the next); then compound 1.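

In this assay, the exchanges on the chain carbon gave only modest movements, but this position responds far more strongly when the whole oxygen-linked group gives way to phenyl: benzyloxy to phenyl gives a 46-fold lower number from compound 3 to compound 4 (1.67 log units; beyond the scatter), isobutoxy to phenyl gives a 45-fold lower number from compound 2 to compound 4 (1.66 log units; beyond the scatter), and butoxy to phenyl gives a 130-fold lower number from compound 1 to compound 4 (2.10 log units; beyond the scatter). An aromatic ring at this position is not enough on its own, since benzyloxy and phenyl each carry one such ring, yet benzyloxy gives only a 1.0-fold higher number from compound 2 to compound 3 (0.01 log units; within the scatter) when it replaces isobutoxy, while phenyl stands far apart from both. The compounds shown offer no evidence on why this change has so large an effect.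

As far as these compounds go, the change to compound 4 removes the oxygen and the chain carbon together, so it remains open which of the two matters, a question that a benzyl group, keeping only the carbon, or a phenoxy group, keeping only the oxygen, could help to separate. From the compounds shown here alone, it is also open how far the low number of compound 4 would survive a methoxy group or a fluorine on the new phenyl ring, or a pyridine ring in its place.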